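Swapping an ether side chain for isopentyl on a shared core

The source may hold more compounds than are shown below. What is called first, only, known or untested is meant among the compounds shown, and "the series" means these compounds.

Of the compounds shown here, three have been measured in a functional assay on a cell-free system (plasma, Homo sapiens), with a stated time of 3 min; a lower number here means a stronger inhibitor, a higher number a weaker inhibitor. Compound 1 `COC(C)(C)[C@@H](O)C(=O)N1N=CC[C@H]1C(=O)NCc1cc(Cl)ccc1-n1cnnn1` gives 3700 nM in this assay, the highest of the three numbers. Among the measured compounds shown here, compound 2 `CC(C)(C)C[C@@H](O)C(=O)N1[C@@H]2C[C@@H]2C[C@H]1C(=O)NCc1cc(Cl)ccc1-n1cnnn1` gives 520 nM and compound 3 `O=C(NCc1cc(Cl)ccc1-n1cnnn1)[C@@H]1C[C@@H]2C[C@@H]2N1C(=O)[C@H](O)c1ccccc1F` gives 770 nM; both sit on a different core from compound 1, so no single-change step to compound 1 exists among them, and the gaps from compound 1 to each of them lie beyond the usual scatter.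

Compound 4 `CC(C)CC[C@@H](O)C(=O)N1N=CC[C@H]1C(=O)NCc1cc(Cl)ccc1-n1cnnn1` keeps the core of compound 1 and changes only the side chain: isopentyl in place of 1-methoxy-1-methylethyl on a saturated chain carbon bound to a carbonyl carbon and an oxygen on a saturated carbon. The group that enters carries no hydrogen-bond acceptor, while the group that leaves carried one.

For the measured compounds named here, with no measured step of this kind, the expectation rests on the other two compounds, whose side chains also lack an ether oxygen and whose numbers are lower. The author therefore expects compound 4 to give a lower number than compound 1, by a step of a 2.5-fold lower number from compound 1 to compound 4 (0.39 log units; beyond the scatter) that is modest and near the edge of the scatter, partly because compound 2 with its saturated side chain gives 520 nM in this assay. Compound 4 is estimated at 1500 nM, within a range from 500 nM to 4500 nM.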

Compound 4, half-maximal inhibitory concentration: 630 nM
Estimate against measurement, compound 4: 2.4-fold (0.38 log units) above; measured number inside the range.
By their numbers in this assay, from the lowest: compounds 2, 4 and 3 (each within the scatter of the next); then compound 1.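

In this assay, isopentyl in place of 1-methoxy-1-methylethyl on a saturated chain carbon bound to a carbonyl carbon and an oxygen on a saturated carbon gives a 5.9-fold lower number from compound 1 to compound 4 (0.77 log units; beyond the scatter), the only single-change step shown, and so establishes that the number on the core of compound 1 responds to the side chain at this position. The two groups have the same count of heavy atoms and neither has a ring, while the hydrogen-bond acceptor is present only in the group that leaves, but this one step cannot separate the loss of that oxygen from the other differences between the two groups. No measurement shown here accounts for the step, which therefore stays unexplained.

On these data alone, it remains open how a cyclohexyl ring, a primary amine or a carboxylic acid at this position would compare with isopentyl on the core of compound 1. Also open, as far as these compounds go, is whether the same exchange would give a step of similar size on the core shared by compound 2 and compound 3.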